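A few compounds are considered here, and "the series" means these few. Any claim that something is new, unique, unknown or untested is made for them only; others in the source may bear on it.

Measured so far in an ADME assay on CCRF-HSB-2 cells (Homo sapiens) for cytotoxicity, with a stated time of 7 days; a lower number here means that less compound is tolerated, a higher number that more compound is tolerated:
- compound 1 `CCCNc1nc(N)nc2c1ncn2/C=C1/CC1(CO)CO`: > 20000 nM
- compound 2 `Nc1nc(NC2CCCC2)c2ncn(/C=C3/CC3(CO)CO)c2n1`: > 20000 nM

Compound 2 has no numeric value on this read-out. Compound 2 gives > 20000 nM, which is a limit of the assay. Compound 1 shares that limit, as the limit of > 20000 nM in this assay, at which 2 of the 2 values shown sit, records.

The next compound, compound 3 `CCCCCCSc1nc(N)nc2c1ncn2/C=C1/CC1(CO)CO`, changes the same place on the shared core: hexylsulfanyl in place of cyclopentylamino on an aromatic carbon. Here hexylsulfanyl takes the place of cyclopentylamino on an aromatic carbon.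

Among the compounds with values here, only one measured step bears on this change. It is a step that the two limits leave unreadable from compound 1 to compound 2, and its size cannot be read. Within the data shown here, that step also keeps the nitrogen on the aromatic ring, while no measured compound carries a sulfanyl group, so it gives only weak guidance. In this assay, the expectation is therefore for no clear step. If a step does appear, it is more likely to be towards less compound tolerated, and a further limit is the likeliest report.

For compound 3 the estimated value is 20000 nM, with an expected range from 7000 nM to 30000 nM. The estimated change is a number no higher from compound 2 to compound 3 (the limit leaves the size open).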

Compound 3, half-maximal cytotoxic concentration: 60000 nM
For compound 3 the middle estimate is 3.0-fold (0.48 log units) below the measured one, outside the stated range (above it).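

In this assay no new step can be read from compound 1 or compound 2 to compound 3, because compound 1 and compound 2 both stand at a limit rather than at a number: the limit of > 20000 nM in this assay, at which 2 of the 3 values shown sit.

The compounds shown leave open how large the difference is between hexylsulfanyl and either propylamino or cyclopentylamino on this read-out.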